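Lengthening the Alkoxy Chain of Compound 2

A few compounds are considered here, and "the series" means these few. Any claim that something is new, unique, unknown or untested is made for them only; others in the source may bear on it.

Measured so far:
compound 1, `CCCCCCCCCCCCCCOc1cc(OC)c(Br)cc1C(C)=O`: 6800000 nM
compound 2, `CCCCCCCCOc1cc(OC)ccc1C(C)=O`: 21200000 nM

In a functional assay, with stated times of 30 s and 6 min, in the presence of a further agent that is not named here (on this read-out higher numbers stand for weaker inhibition and lower numbers for stronger inhibition), compound 2 gives the highest of the two numbers. Among the measured compounds shown here, its only neighbour, compound 1, gives a number that is lower by more than the usual scatter, but compound 1 differs from compound 2 in more than one place, so that gap cannot be tied to a single change.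

Compound 3, `CCCCCCCCCCCCCCOc1cc(OC)ccc1C(C)=O`, has not been measured yet. It differs from compound 2 by hexyl in place of hydrogen on a saturated chain carbon, eight bonds along the chain from an oxygen on an aromatic ring. For the measured compounds named here, no pair of measured compounds shows the effect of this change on its own; the only hint is the lower number of compound 1. A modest move toward stronger inhibition is therefore expected, roughly a 2.4-fold lower number from compound 2 to compound 3 (0.37 log units; beyond the scatter), although a result within the scatter would not surprise. Compound 3 is expected to give about 9000000 nM, within a range from 3000000 nM to 25000000 nM.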

Compound 3, half-maximal inhibitory concentration: 35900000 nM
For compound 3 the middle estimate is 4.0-fold (0.60 log units) below the measured one; the measured number lies above the stated range.
By their numbers in this assay, from the lowest: compound 1; then compounds 2 and 3 (each within the scatter of the next).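

In this assay hexyl in place of hydrogen on a saturated chain carbon, eight bonds along the chain from an oxygen on an aromatic ring, gives a 1.7-fold higher number from compound 2 to compound 3 (0.23 log units; within the scatter) and so leaves the two chain lengths indistinguishable here. Compound 1 can now be compared across a single change: hydrogen in place of bromo on an aromatic carbon gives a 5.3-fold higher number from compound 1 to compound 3 (0.72 log units; beyond the scatter) and ties its lower number to the bromo rather than to the chain. Nothing available explains the size of either step.

Still open, on these data alone, is whether a chain ending in an amine or a carboxylic acid would move the number at this position. Also open, as far as these compounds go, is whether bromo would give a similar step on the octyl chain of compound 2.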